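A few compounds are considered here, and "the series" means these few. Any claim that something is new, unique, unknown or untested is made for them only; others in the source may bear on it.

Compound 1 `CCCN(C)C(=O)c1ccc(-c2cc(-c3cc(OC)ccc3OC)no2)s1`, compound 2 `CCN(CC)C(=O)c1ccc(-c2cc(-c3cc(OC)ccc3OC)no2)s1` and compound 3 `COc1ccc(CN(C)C(=O)c2ccc(-c3cc(C4=CC(=O)C=CC4=O)no3)s2)cc1` share one core and were tested in a functional assay on A549 cells (Homo sapiens) for cytotoxicity, read by XTT assay, with a stated time of 72 h; on this read-out higher numbers stand for weaker inhibition and lower numbers for stronger inhibition. In this assay compound 1 gives only a limit of the assay, > 30000 nM. In this assay compound 2 gives 11000 nM. For the measured compounds named here, the one measured step, an at least 2.7-fold lower number from compound 1 to compound 2 (0.43 log units; beyond the scatter), concerns the amide and nothing else. In this assay compound 3 gives only a limit of the assay, > 30000 nM. Compound 3 thus sits at the limit of > 30000 nM in this assay, at which 2 of the 3 values shown sit, so its true number is not known.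

Compound 4 `COc1ccc(CN(C)C(=O)c2ccc(-c3cc(-c4cc(OC)ccc4OC)no3)s2)cc1` differs from compound 3 by a group of 10 heavy atoms (8 carbon, 2 oxygen; one six-membered aromatic ring of carbon only) in place of a group of 8 heavy atoms (6 carbon, 2 oxygen; one six-membered non-aromatic ring of carbon only), on an aromatic carbon. Going by the values given here, no measured step follows this change. Compounds 1 and 2 already carry the 2,5-dimethoxyphenyl group that enters here, and they show one limit and one weak number, so the group by itself does not bring strong inhibition in this assay. The step from compound 1 to compound 2 bears on compound 4 only in that the amide of compound 4 differs from both.

Compound 4 is therefore expected to stay weak in this assay, with an estimated 20000 nM, in the range 7000 nM to 60000 nM, and an expected step of an at least 1.5-fold lower number from compound 3 to compound 4 (0.17 log units; that floor lies within the scatter) that cannot be called beyond the scatter since compound 3 is a limit.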

Compound 4, half-maximal inhibitory concentration: > 30000 nM
Compound 4 was reported as a limit (the forecaster's own chance of this, stated with the estimate: 50%); middle value at least 1.5-fold (0.17 log units) from the limit.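

Replacing diethylamino with (4-methoxybenzyl)(methyl)amino on the amide carbonyl carbon, with the 2,5-dimethoxyphenyl group held in place, gives an at least 2.7-fold higher number from compound 2 to compound 4 (0.43 log units; beyond the scatter) in this assay, so among the compounds shown only the diethylamino amide carrying that group reads as a number. The steps from compound 3 to compound 4 and from compound 1 to compound 4 join two limits and cannot be read, so the exchange of the non-aromatic ring group for 2,5-dimethoxyphenyl, on the aromatic carbon next to the ring nitrogen, has no readable size here. Compound 4 thus joins the compounds that give only a limit, and the group on that carbon and the benzyl-type amide are not separated from the limit: the limit of > 30000 nM in this assay, at which 3 of the 4 values shown sit.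

The compounds shown leave open how far the true numbers of compound 1, compound 3 and compound 4 lie from that limit, and whether the non-aromatic ring group would give a readable number when paired with the diethylamino amide. They also leave open whether a dipropylamino or pyrrolidine amide would extend the gain seen with diethylamino, or whether a carboxylic acid or an amine on the benzyl ring would bring a number back.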